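Cutting the Long Ether Chain of Compound 1

A few compounds are considered here, and "the series" means these few. Any claim that something is new, unique, unknown or untested is made for them only; others in the source may bear on it.

In a functional assay on LoVo cells (Homo sapiens) for inhibition, read by colorimetric assay and MTT assay, with a stated time of 72 h (on this read-out higher numbers stand for weaker inhibition and lower numbers for stronger inhibition), compound 1 `C=CCCCCOc1ccccc1-c1cnc(OCCC=C)n1C` gives 12000 nM, the lowest of the three numbers measured. Compound 2 `C=CCCCCOc1ccc(C)cc1-c1cnc(OCCC=C)n1C` gives 41000 nM, and compound 3 `C=CCCCCOc1cc(F)ccc1-c1cnc(OCCC=C)n1C` gives 45000 nM. Compound 4 `C=CCCOc1ncc(-c2ccccc2OC)n1C` differs from compound 1 by hydrogen in place of pent-4-en-1-yl on a saturated chain carbon bound to an oxygen on an aromatic ring, turning (hex-5-en-1-yl)oxy into methoxy. For the measured compounds named here, no measured step touches this chain, so the guides are indirect. Methyl in place of hydrogen on an aromatic carbon gave a 3.4-fold higher number from compound 1 to compound 2 (0.53 log units; beyond the scatter), and fluoro in place of hydrogen on an aromatic carbon gave a 3.8-fold higher number from compound 1 to compound 3 (0.57 log units; beyond the scatter). A modest step of similar size is therefore expected in this assay, again toward weaker inhibition, namely a 2.9-fold higher number from compound 1 to compound 4 (0.46 log units; beyond the scatter). The estimated value for compound 4 is 35000 nM, with an expected range from 12000 nM to 100000 nM.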

Compound 4, half-maximal inhibitory concentration: 24000 nM
Compound 4: the middle estimate sits 1.5-fold (0.16 log units) above what was measured; measured number inside the range.
By their numbers in this assay, from the lowest: compounds 1, 4, 2 and 3 (each within the scatter of the next, the first and the last beyond it).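

For the compounds shown here, the ether chain on the aromatic ring proves more tolerant of change than the aromatic carbons probed in the earlier compounds: in this assay, hydrogen in place of pent-4-en-1-yl gives a 2.0-fold higher number from compound 1 to compound 4 (0.30 log units; within the scatter). Thus, turning (hex-5-en-1-yl)oxy into methoxy leaves no change that can be read beyond the scatter, so this assay shows no need for the longer chain. Nothing given here explains this result.

From the compounds shown here alone, whether an ethoxy or butoxy chain would fit the same picture remains open. So does the effect of a terminal amine or carboxylic acid on this chain.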